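Phenyl to 4-fluorophenyl in a cell viability series

A few compounds are considered here, and "the series" means these few. Any claim that something is new, unique, unknown or untested is made for them only; others in the source may bear on it.

Compound 1 `Fc1ccc2nc(-c3cc(-c4ccccc4)n(-c4ccccc4)n3)ccc2c1` was examined in an ADME assay on Huh-7 cells (Homo sapiens) for cytotoxicity, read by XTT assay, with a stated time of 3 days, tested at 20 uM (on this read-out higher numbers stand for a weaker effect at the one concentration tested and lower numbers for a stronger effect), where compound 1 gives 124%. Compound 2 `Fc1ccc(-c2cc(-c3ccc4cc(F)ccc4n3)nn2-c2ccccc2)cc1` carries one change relative to compound 1, (fluoro in place of hydrogen on an aromatic carbon), and in this assay compound 2 gives 88.3%. The step of a number 35.7 percentage points lower from compound 1 to compound 2 (beyond the scatter) is the only measured effect of this change in the set.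

Compound 3 `COc1ccc(-n2nc(-c3ccccc3)cc2-c2ccc3cc(F)ccc3n2)cc1` shares the same change of phenyl to 4-fluorophenyl still to come; in this assay compound 3 gives 116%. The difference between the core of compound 3 and the core of compound 1 is not broken down here, and their values lie within the scatter of each other.

Compound 4 `COc1ccc(-n2nc(-c3ccc(F)cc3)cc2-c2ccc3cc(F)ccc3n2)cc1` has not yet been measured in this assay. It differs from compound 3 by fluoro in place of hydrogen on an aromatic carbon, the same change that turned compound 1 into compound 2, at a place described in the same words. Because the step of a number 35.7 percentage points lower from compound 1 to compound 2 (beyond the scatter) was large, a lowering is expected from compound 3 to compound 4, estimated at a number 31 percentage points lower from compound 3 to compound 4 (beyond the scatter), resting on that single precedent only. On this basis compound 4 is expected to give about 85%, with a range from 60% to 112%.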

Compound 4, a percentage reported as activity, at one concentration (the size of the read-out at that concentration, not a potency): 89.1%
Estimate against measurement, compound 4: 4.1 percentage points below, and the stated range covers the measured number.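

In this assay the change from phenyl to 4-fluorophenyl gives a number 26.9 percentage points lower from compound 3 to compound 4 (beyond the scatter) and so repeats the direction of a number 35.7 percentage points lower from compound 1 to compound 2 (beyond the scatter) on a second core. Set side by side, the two steps agree in direction and cannot be told apart in size: the same change on two cores in this assay, a number 35.7 percentage points lower (beyond the scatter) from compound 1 to compound 2 and a number 26.9 percentage points lower (beyond the scatter) from compound 3 to compound 4, 8.8 percentage points apart, within the scatter of two such steps

This shows that the lowering carried over from the core of compound 1 to the core of compound 3, so the earlier step was a fair guide here, but it rests on two pairs only, read at a single concentration in one cell line, and it does not show why the number falls or that the step would hold on any further core.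

The compounds shown leave open whether another group in the same place, such as chloro, a nitrile or a carboxylic acid, would move the number in the same way. They also leave open what a fluoro at another place on that ring would do.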